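The source may report more compounds than this note shows. Statements on the series, on what has been measured and on what is new or still open speak of the compounds shown alone.

Three compounds share one core and differ only in the aryl group carried on an aromatic nitrogen of that core. Compound 1 `Cc1ccccc1-n1cc(COc2cccc(NC(=O)Nc3ccc(Cl)c(C(F)(F)F)c3)c2)nn1` carries a 2-methylphenyl group there; in a functional assay on HepG2 cells (Homo sapiens) for inhibition, read by MTT assay, with a stated time of 72 h (a lower number here means a stronger inhibitor, a higher number a weaker inhibitor), compound 1 gives 3440 nM. Compound 2 `N#Cc1ccccc1-n1cc(COc2cccc(NC(=O)Nc3ccc(Cl)c(C(F)(F)F)c3)c2)nn1` bears a 2-cyanophenyl group, and in this assay compound 2 gives 1970 nM. Compound 3 `O=C(Nc1cccc(OCc2cn(-c3ccc(I)cc3)nn2)c1)Nc1ccc(Cl)c(C(F)(F)F)c1` bears a 4-iodophenyl group, and in this assay compound 3 gives 2690 nM. The number for compound 3 sits between those of compound 2 and compound 1, and each gap lies within the scatter: a 1.3-fold lower number from compound 1 to compound 3 (0.11 log units; within the scatter) and a 1.4-fold higher number from compound 2 to compound 3 (0.14 log units; within the scatter). Exchanging the substituent on the aryl group also stayed within the scatter: a 1.7-fold lower number from compound 1 to compound 2 (0.24 log units; within the scatter).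

Compound 4 `O=C(Nc1cccc(OCc2cn(-c3ccccc3C(F)(F)F)nn2)c1)Nc1ccc(Cl)c(C(F)(F)F)c1` continues the same variation: 2-(trifluoromethyl)phenyl in place of 4-iodophenyl on an aromatic nitrogen. Every step that alters this aryl group has stayed within the scatter, so compound 4 is expected to give no step beyond the scatter, a 1.0-fold lower number from compound 3 to compound 4 (0.01 log units; within the scatter). In this assay compound 4 is therefore estimated at 2600 nM, within a range from 1200 nM to 5500 nM.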

Compound 4, half-maximal inhibitory concentration: 2320 nM
Compound 4: middle estimate off by 1.1-fold (0.05 log units), on the high side; the measured number falls inside the stated range.
By their numbers in this assay, from the lowest: compounds 2, 4, 3 and 1 (each within the scatter of the next).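

Putting 2-(trifluoromethyl)phenyl on the aromatic nitrogen, with 10 heavy atoms where 4-iodophenyl has 7, still gives a 1.2-fold lower number from compound 3 to compound 4 (0.06 log units; within the scatter) in this assay, and this group has fluorine where 4-iodophenyl has iodine. Trifluoromethyl also keeps within the scatter when it stands in place of the other two aryl substituents, with a 1.2-fold higher number from compound 2 to compound 4 (0.07 log units; within the scatter) against cyano and a 1.5-fold lower number from compound 1 to compound 4 (0.17 log units; within the scatter) against methyl, so all four aryl groups now shown give numbers within the scatter of one another, and none goes against this. No measurement shown here accounts for how little these exchanges change the number.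

From the compounds shown here alone, it remains open whether an amine or a carboxylic acid on this aryl group, or a longer chain in its place, would give a step beyond the scatter. Going by these compounds, whether the same holds with other groups elsewhere on the shared core also remains open.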